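This account rests on a few compounds, and the source may have more. Where it says the series, first, only, none or still open, it means among the compounds named here.

Measured in an ADME assay on microsomes from liver (Homo sapiens) for metabolic stability, with a stated time of 10 min; on this read-out lower numbers stand for a less stable compound and higher numbers for a more stable compound:
Compound 1 `FC(F)(F)Oc1ccccc1-c1ccc2[nH]c(C3=NOC4(CCCCC4)C3)nc2c1`: 100%
Compound 2 `FC(F)Oc1ccccc1-c1ccc2[nH]c(C3=NOC4(CCCCC4)C3)nc2c1`: 100%
Compound 3 `Fc1cccc(OC(F)(F)F)c1-c1ccc2[nH]c(C3=NOC4(CCCCC4)C3)nc2c1`: 100%

Compounds 2 and 3 stand level with compound 1 at 100%, so compound 1 is neither above nor below the other two in this assay. The unmeasured compound 4 `FC(F)(F)Oc1ccccc1-c1cc(C(F)(F)F)c2[nH]c(C3=NOC4(CCCCC4)C3)nc2c1` carries trifluoromethyl in place of hydrogen on an aromatic carbon of the core of compound 1 (trifluoromethyl in place of hydrogen on an aromatic carbon).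

Going by the values given here, two measured steps bear on this change. The closer one is no change at the digits printed from compound 1 to compound 3 (within the scatter), where fluoro replaces hydrogen on an aromatic carbon. The other is no change at the digits printed from compound 1 to compound 2 (within the scatter), where hydrogen replaces fluoro on a saturated chain carbon bound to two fluorine atoms and an oxygen on an aromatic ring. Among the compounds with values here, neither step moved the read-out, but neither places trifluoromethyl on the core, so the support is indirect and the data hold no direct precedent for this change. No shift beyond the scatter is therefore expected, with some allowance for a lower reading.

The expected step is a number 4 percentage points lower from compound 1 to compound 4 (within the scatter). For compound 4 the estimated value is 96%, with an expected range from 82% to 100%.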

Compound 4, percent of the compound remaining: 51%
For compound 4 the middle estimate is 45 percentage points above the measured one; the measured number lies below the stated range.
By their numbers in this assay, from the lowest: compound 4; then compounds 1, 2 and 3 (each within the scatter of the next).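

In this assay, trifluoromethyl in place of hydrogen on an aromatic carbon of the core, ortho to a fused ring and meta to a 2-(trifluoromethoxy)phenyl group, gives a number 49 percentage points lower from compound 1 to compound 4 (beyond the scatter), which makes this the first position among the compounds shown where a change moves the read-out. The two earlier steps, compound 2 and compound 3, altered only the phenyl ring bearing the fluorinated ether and left the read-out level, so they gave no sign that a single substitution on the core could have a large effect. The information at hand gives no measured explanation for this drop.

Among the compounds shown, only compound 4 carries a group on this carbon, so it remains open whether the drop belongs to trifluoromethyl itself or would also appear with a fluoro, a methyl, a methoxy or a nitrile at the same place. From the compounds shown here alone, it also remains open whether trifluoromethyl on the other aromatic carbons of the core would lower the read-out in the same way.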